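Methoxy for chloro on the aryl ring of compound 3

The source may report more compounds than this note shows. Statements on the series, on what has been measured and on what is new or still open speak of the compounds shown alone.

Of the compounds shown here, three sharing one core have been measured in a functional assay on MCF7 cells (Homo sapiens) for antiproliferative activity, read by sulforhodamine B assay, with a stated time of 48 h; a lower number here means a stronger inhibitor of growth, a higher number a weaker inhibitor of growth. Compound 1 `COc1ccc(Cn2cc(CNC(=O)c3cn(-c4ccccc4)nc3-c3ccc(Cl)cc3)nn2)cc1` gives 8000 nM. Compound 2 `COc1ccc(Cn2cc(CNC(=O)c3cn(-c4ccccc4)nc3-c3ccc(Cl)cc3)nn2)cc1OC` reaches only the limit of the assay, > 100000 nM, and no number. Compound 3 `COc1cc(Cn2cc(CNC(=O)c3cn(-c4ccccc4)nc3-c3ccc(Cl)cc3)nn2)cc(OC)c1OC` gives 2500 nM. The step of an at least 12-fold higher number from compound 1 to compound 2 (1.09 log units; beyond the scatter) was thus large, while a 3.2-fold lower number from compound 1 to compound 3 (0.51 log units; beyond the scatter) was modest and an at least 40-fold lower number from compound 2 to compound 3 (1.60 log units; beyond the scatter) again large; the limit itself is recorded as the limit of > 100000 nM in this assay, at which 1 of the 3 values shown sits. Among the two numbers shown, compound 3 has the lowest, and compound 1 is nearest to it.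

Compound 4 `COc1ccc(-c2nn(-c3ccccc3)cc2C(=O)NCc2cn(Cc3cc(OC)c(OC)c(OC)c3)nn2)cc1` differs from compound 3 in one place: methoxy in place of chloro on an aromatic carbon. Within the data shown here, none of the measured steps touches this ring; all three concern the methoxy pattern on the benzyl group, so they bear on the new change only indirectly, as a sign that single substituent swaps can move the number either way. Among the measured compounds shown here, with no direct precedent, the expected step of a 1.2-fold higher number from compound 3 to compound 4 (0.08 log units; within the scatter) from compound 3 to compound 4 is none beyond the scatter, with a wide allowance in both directions. Compound 4 is therefore estimated at 3000 nM, within a range from 800 nM to 12000 nM.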

Compound 4, concentration for 50% growth inhibition: 7600 nM
For compound 4 the middle estimate is 2.5-fold (0.40 log units) below the measured one; low and high end bracket the measured number.
By their numbers in this assay, from the lowest: compound 3; then compounds 4 and 1 (each within the scatter of the next). At a limit, above all of these: compound 2.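

Until compound 4, every step shown concerned the methoxy pattern on the benzyl group, so this is the first reading of the other aromatic ring: in this assay the change from 4-chlorophenyl to 4-methoxyphenyl gave a 3.0-fold higher number from compound 3 to compound 4 (0.48 log units; beyond the scatter), which shows that the number responds to the group at this position. Of this pair, compound 3 with its chloro group holds the lower number, and the step is printed as modest, whereas the steps that added a methoxy group to the benzyl ring of compound 1 and of compound 2 are of different sizes and run in opposite directions, so a methoxy group has no single effect across the series. Nothing shown here accounts for the rise at this position.

From the compounds shown here alone, only chloro and methoxy appear at this position, so how an amine, a hydroxyl group or a nitrile there would read remains open. Also open, going by these compounds, is whether the same swap would give a step of similar size and direction with the benzyl pattern of compound 1 in place of that of compound 3.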